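Tert-butyl for methoxymethyl on the fused bicyclic core

The source may report more compounds than this note shows. Statements on the series, on what has been measured and on what is new or still open speak of the compounds shown alone.

Measured so far in a functional assay for inhibition, with Homo sapiens as the target; a higher number here means a weaker inhibitor, a lower number a stronger inhibitor:
- compound 1, `Cc1nc(C(C)(C)C)n2c(O)nncc12`: 31000 nM
- compound 2, `COCc1ncc2cnnc(O)n12`: > 48000 nM

Compound 2 stands at the edge of what this assay can report. The value given for compound 2 is a limit of the assay, not a number, and the set has (the limit of > 48000 nM in this assay, at which 1 of the 2 values shown sits). Going by the values given here, compound 1 gives a number in this assay, 31000 nM, but it differs from compound 2 in more than one place, so no single step between the two is drawn.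

Compound 3, `CC(C)(C)c1ncc2cnnc(O)n12`, follows from compound 2 by one change: tert-butyl in place of methoxymethyl on an aromatic carbon. Compound 1 carries the same tert-butyl group and returns a measurable value, which is the only hint available for where compound 3 may land. A modest gain, of a size that may or may not exceed the scatter, is the expectation, with a real chance that the readout again reaches the limit. The step from compound 2 to compound 3 is estimated as an at least 1.0-fold lower number from compound 2 to compound 3 (0.02 log units; that floor lies within the scatter). For compound 3 the expected value in this assay is 45000 nM, ranging from 20000 nM to 100000 nM.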

Compound 3, half-maximal inhibitory concentration: > 48000 nM
Compound 3: only a limit was reported (the forecaster's own chance of this, stated with the estimate: 50%); at least 1.0-fold (0.02 log units) between middle value and limit.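

In this assay compound 3 gives > 48000 nM, which is a limit of the assay and not a number. Tert-butyl in place of methoxymethyl, on an aromatic carbon between two ring nitrogen atoms, therefore leaves the readout at the limit, and the step between compound 2 and compound 3 cannot be read. Hydrogen in place of methyl on an aromatic carbon is the only change in the one readable step, an at least 1.5-fold higher number from compound 1 to compound 3 (0.18 log units; that floor lies within the scatter), so the methyl group cannot yet be tied to a real difference, and the series now sits largely at the edge of what this readout can report: the limit of > 48000 nM in this assay, at which 2 of the 3 values shown sit.

Going by these compounds, whether methoxymethyl and tert-butyl differ at all at this position stays open, and only a pair with two numbers in this assay could settle it. On these data alone, it is equally open whether a different group on this carbon, such as an amine or a phenyl ring, would bring the shared core into the readable range, and whether a methyl group on the core would do so with methoxymethyl in place.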